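A few compounds are considered here, and "the series" means these few. Any claim that something is new, unique, unknown or untested is made for them only; others in the source may bear on it.

Compound 2 `COc1cccc(Oc2ccc3cc(NC(=O)c4ccc(O)c(CC=C(C)C)c4)c(=O)oc3c2C)c1` shares its core with compound 1 `COc1cccc(Oc2ccc3cc(NC(=O)c4ccc(OC(C)=O)c(CC=C(C)C)c4)c(=O)oc3c2C)c1` and compound 3 `COc1cccc(-c2cc(C(=O)Nc3cc4ccc(Oc5ccc(C(C)(C)C)cc5)c(C)c4oc3=O)ccc2OC)c1`. Among the compounds with values here, in a functional assay on MCF7 cells (Homo sapiens) for antiproliferative activity (a higher number here means a weaker inhibitor, a lower number a stronger inhibitor), compound 1 gives 15700 nM, and compound 2 gives 62800 nM; the change a 4.0-fold higher number from compound 1 to compound 2 (0.60 log units; beyond the scatter) is the only measured step, so compound 2 stands highest of the two numbers. For compound 3 the assay reports only a limit, > 100000 nM, as described by the limit of > 100000 nM in this assay, at which 1 of the 3 values shown sits. Compound 4 `COc1cccc(Cc2ccc3cc(NC(=O)c4ccc(O)c(CC=C(C)C)c4)c(=O)oc3c2C)c1` differs from compound 2 by 3-methoxybenzyl in place of 3-methoxyphenoxy on an aromatic carbon. Within the data shown here, no measured step bears on this change, since the one step measured, a 4.0-fold higher number from compound 1 to compound 2 (0.60 log units; beyond the scatter), concerns a different group, so no shift beyond the scatter is expected in this assay. Compound 4 is therefore estimated at 60000 nM, within 20000 nM to 150000 nM. That estimate is expected to mean the step of a 1.0-fold lower number from compound 2 to compound 4 (0.02 log units; within the scatter).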

Compound 4, half-maximal inhibitory concentration: 19700 nM
Compound 4: middle estimate off by 3.0-fold (0.48 log units), on the high side, and the stated range ends above it.
By their numbers in this assay, from the lowest: compounds 1 and 4 (each within the scatter of the next); then compound 2. At a limit, above all of these: compound 3.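

Placing 3-methoxybenzyl in place of 3-methoxyphenoxy on this aromatic carbon, ortho to a methyl group, gives a 3.2-fold lower number from compound 2 to compound 4 (0.50 log units; beyond the scatter) in this assay, so this position responds to a change beyond the scatter. The two groups have the same number of heavy atoms and differ in the atom that joins the ring to the core, so even this small swap registers. Nothing measured here accounts for the shift. From the compounds shown here alone, whether an amine as the joining group, or a longer chain, would move the number further remains open.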